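A few compounds are considered here, and "the series" means these few. Any claim that something is new, unique, unknown or untested is made for them only; others in the source may bear on it.

Measured so far in a functional assay on PANC-1 cells (Homo sapiens) for inhibition, read by MTT assay, with a stated time of 24 h, tested at 10 uM; a lower number here means less inhibition, a higher number more inhibition at the concentration tested (going by the name of the read-out):
compound 1 `CC(C)=CCC1Cc2c(O)cc(=O)n(CCCO)c2CC1(C)C` gives 25.6%
compound 2 `COc1ccccc1NC(=O)Oc1cc(=O)n(CCCO)c2c1CC(CC=C(C)C)C(C)(C)C2` gives 71.1%

Within the data shown here, compound 2 stands highest of the two numbers, with compound 1 the only neighbour and well below it. Among the measured compounds shown here, the one measured step, a number 45.5 percentage points higher from compound 1 to compound 2 (beyond the scatter), is large and beyond the scatter; it adds the carbamate as a whole. Compound 3 `CC(C)=CCC1Cc2c(OC(=O)Nc3ccc(F)cc3)cc(=O)n(CCCO)c2CC1(C)C` keeps that carbamate and alters only the aryl on it: 4-fluorophenyl in place of 2-methoxyphenyl on an amide-type nitrogen. No measured step varies the aryl group on the amide-type nitrogen, so nothing shown bears directly on this change. Because compound 2 gives 71.1% with the carbamate in place, compound 3 is expected to remain near that level, a step of a number 6.1 percentage points lower from compound 2 to compound 3 (within the scatter) within the scatter, estimated at 65% in a range of 40% to 85%.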

Compound 3, a percentage reported as inhibition, at one concentration (the size of the read-out at that concentration, not a potency): 71.2%
The estimate for compound 3 lay 6.2 percentage points below the measured number; measured number inside the range.
By their numbers in this assay, from the lowest: compound 1; then compounds 2 and 3 (each within the scatter of the next).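

In this assay, the exchange on the amide-type nitrogen stays within the scatter, a number 0.1 percentage points higher from compound 2 to compound 3 (within the scatter), so 2-methoxyphenyl and 4-fluorophenyl cannot be told apart at this position. The large step from hydrogen on the oxygen, a number 45.6 percentage points higher from compound 1 to compound 3 (beyond the scatter), now holds for two aryl carbamates rather than one. Nothing here gives a reason for either step.

Open, going by these compounds, is whether a benzyl group or a simple alkyl chain on that nitrogen keeps the number. Also open, on these data alone, is whether an acetyl ester on the oxygen, lacking the amide-type nitrogen, does the same.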